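A Propyl Chain in Place of Trifluoromethyl

A few compounds are considered here, and "the series" means these few. Any claim that something is new, unique, unknown or untested is made for them only; others in the source may bear on it.

Compound 1 `CN1CCC[C@H]1COc1cccnc1Br` gives 451 nM.
Compound 2 `CN1CCC[C@H]1COc1cncc(C(F)(F)F)c1` gives 1.83 nM.

Both numbers come from an assay on membranes from brain for displacement of a labelled ligand from Neuronal acetylcholine receptor; alpha4/beta2 (Rattus norvegicus); on this read-out higher numbers stand for weaker inhibition and lower numbers for stronger inhibition. On this scale compound 2 stands lowest of the two, and compound 1 is the only other point, with a number far higher than compound 2, a gap well beyond the usual scatter. Within the data shown here, the two compounds differ in more than one place, so their two values show only that the trifluoromethyl-bearing compound 2 binds far more strongly; no single change is isolated by them.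

Compound 3 `CCCc1cncc(OC[C@@H]2CCCN2C)c1` has not yet been measured. It differs from compound 2 in one spot: propyl in place of trifluoromethyl on an aromatic carbon, the propyl sitting on an aromatic carbon of the six-membered aromatic ring with one nitrogen, two atoms from the ring nitrogen. Among the measured compounds shown here, no pair of measured compounds differs only in this way, so there is no measured step to lean on. A modest weakening seems the most likely outcome, but a result within the scatter of compound 2 cannot be ruled out. For compound 3 the estimate is 8 nM, within 1.5 nM to 45 nM, which corresponds to an expected step of a 4.4-fold higher number from compound 2 to compound 3 (0.64 log units; beyond the scatter).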

Compound 3, inhibition constant: 0.12 nM
The estimate for compound 3 lay 67-fold (1.82 log units) above the measured number; the measured number lies below the stated range.
By their numbers in this assay, from the lowest: compound 3; then compound 2; then compound 1.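

In this assay, among these compounds, the exchange of trifluoromethyl for propyl on this aromatic carbon gives a 15-fold lower number from compound 2 to compound 3 (1.18 log units; beyond the scatter) and is the first single change that can be read on its own. It shows that trifluoromethyl is not required here for strong binding, since a plain carbon chain with no fluorine gives a clearly lower number on the same core, and that the group on this carbon has a large influence on the result. The data offered here give no explanation for this gain.

Among the compounds shown here, only two groups can be compared at this carbon, so it remains open whether the gain is specific to propyl or would also appear with a shorter ethyl chain, a longer butyl chain, a branched isopropyl group or an amine in the same place. Going by these compounds, it also remains open whether the same exchange would have an effect of similar size on a different core, such as the core of compound 1.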